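Three sulfonamides without measurable toxicity, and a fourth

The source may hold more compounds than are shown below. What is called first, only, known or untested is meant among the compounds shown, and "the series" means these compounds.

Compound 1 `COc1ccccc1S(=O)(=O)Nc1ccc(-c2nc3ccccc3o2)cc1` — in an ADME assay on HEK293 cells (Homo sapiens) for cytotoxicity, read by resazurin assay, with a stated time of 48 h (on this read-out lower numbers stand for higher toxicity in this test and higher numbers for lower toxicity in this test), compound 1 gives > 100000 nM, a limit of the assay.
Compound 2 `O=S(=O)(Nc1ccc(-c2nc3ccccc3o2)cc1)c1ccc(F)cc1` — in this assay compound 2 gives > 100000 nM, also a limit.
Compound 3 `O=S(=O)(Nc1ccc(-c2nc3ccccc3o2)cc1)c1ccc(O)cc1` — in this assay compound 3 gives > 100000 nM, again a limit.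

All three measured compounds therefore sit at the same point, (the limit of > 100000 nM in this assay, at which 3 of the 3 values shown sit). Compound 3 stands there with the others; nothing shown distinguishes it from compound 1 or compound 2. The steps among the measured compounds are accordingly unreadable: a step that the two limits leave unreadable from compound 1 to compound 2, a step that the two limits leave unreadable from compound 1 to compound 3 and a step that the two limits leave unreadable from compound 2 to compound 3.

Compound 4 `O=S(=O)(Nc1ccc(-c2nc3ccccc3o2)cc1)c1ccc(Cl)cc1` differs from compound 3 as follows: chloro in place of hydroxy on an aromatic carbon. Going by the values given here, the one measured step that touches the same position, a step that the two limits leave unreadable from compound 2 to compound 3, exchanges hydroxy for fluoro and gives no readable size, so it offers no direction for chloro in place of hydroxy. With every measured value at the limit, no step beyond the scatter in this assay is expected in either direction; the step of a number no higher from compound 3 to compound 4 (the limit leaves the size open) is an estimate resting only on the three limits.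

Compound 4 is therefore expected to give about 100000 nM, within 40000 nM to 300000 nM, most likely reported as a limit again.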

Compound 4, half-maximal cytotoxic concentration: > 100000 nM
Compound 4 was reported as a limit; the forecaster's own chance of this, stated with the estimate: 70%; the middle value sits exactly at the limit.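

Compound 4 joins compound 1, compound 2 and compound 3 as a limit, so no step from any of them to compound 4 can be read: the limit of > 100000 nM in this assay, at which 4 of the 4 values shown sit.

The compounds shown leave open whether the four differ at all in this assay, and whether any group on the sulfonyl sulfur would give a measurable cytotoxic concentration.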